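Changing the nitrogen substituent: compound 3 to compound 4

The source may report more compounds than this note shows. Statements on the series, on what has been measured and on what is new or still open speak of the compounds shown alone.

Measured so far in a functional assay on PC-3 cells (Homo sapiens) for antiproliferative activity, read by sulforhodamine B assay, with a stated time of 72 h; a higher number here means a weaker inhibitor, a lower number a stronger inhibitor:
- compound 1 `COc1ncc(-c2ccc3ncc(NCc4ccc(C(F)(F)F)cc4)c(OC)c3c2)cc1NS(=O)(=O)c1ccc(F)cc1F`: 2880 nM
- compound 2 `COc1ncc(-c2ccc3ncc(NCc4ccccc4)c(OC)c3c2)cc1NS(=O)(=O)c1ccc(F)cc1F`: 4320 nM
- compound 3 `COc1ncc(-c2ccc3ncc(NCC4CCN(S(C)(=O)=O)CC4)c(OC)c3c2)cc1NS(=O)(=O)c1ccc(F)cc1F`: 2850 nM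

Compound 3 cannot be separated from the other two compounds: the data show a 1.0-fold lower number from compound 1 to compound 3 (0.00 log units; within the scatter) and a 1.5-fold lower number from compound 2 to compound 3 (0.18 log units; within the scatter). The next change gives compound 4 `COc1ncc(-c2ccc3ncc(NC(=O)CN4CCCC(O)C4)c(OC)c3c2)cc1NS(=O)(=O)c1ccc(F)cc1F`, with ((3-hydroxypiperidin-1-yl)methyl)carbonyl in place of (1-(methylsulfonyl)piperidin-4-yl)methyl on a nitrogen on an aromatic ring.

The bearing steps are these two, along with a 1.5-fold higher number from compound 1 to compound 2 (0.18 log units; within the scatter). All three alter the group carried on that nitrogen, and none leaves the scatter. Among the compounds with values here, none of the measured compounds has a carbonyl on that nitrogen, however, so this part of the change is untested and the range is kept wide. In this assay, no step beyond the scatter is expected, and the estimate is a 1.1-fold higher number from compound 3 to compound 4 (0.02 log units; within the scatter). For compound 4 the expected value is 3000 nM, with an estimated range of 1000 nM to 9000 nM.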

Compound 4, half-maximal inhibitory concentration: 1340 nM
For compound 4 the middle estimate is 2.2-fold (0.35 log units) above the measured one, within the range that was stated.
By their numbers in this assay, from the lowest: compound 4; then compounds 3, 1 and 2 (each within the scatter of the next).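

In this assay, within the data shown here, the ((3-hydroxypiperidin-1-yl)methyl)carbonyl group gives the first steps at this nitrogen that lie beyond the scatter, all modest (a 2.1-fold lower number from compound 3 to compound 4 (0.33 log units; beyond the scatter); a 2.1-fold lower number from compound 1 to compound 4 (0.33 log units; beyond the scatter); a 3.2-fold lower number from compound 2 to compound 4 (0.51 log units; beyond the scatter)). The three earlier groups, benzyl, 4-(trifluoromethyl)benzyl and (1-(methylsulfonyl)piperidin-4-yl)methyl, could not be separated from one another, so compound 4 alone stands apart, with the lowest number of the four. No measurement shown here accounts for this step.

The carbonyl and the hydroxy group enter together, so the compounds shown do not tell which of them goes with the lower number. A piperidin-1-yl ring without the hydroxy group on the same methylcarbonyl, or a longer chain in place of that methyl, would help to separate the two.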